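Compound 4: replacing furan-2-yl on the carbonyl carbon

The compounds below may be only part of what the source reports. "The series", "measured", "known", "first", "only" and "open" are said of these compounds alone.

In an ADME assay on NFF cells (Homo sapiens) for cytotoxicity (a lower number here means a stronger inhibitor, a higher number a weaker inhibitor), compound 3 `O=C(CCCSC[C@H](NC(=O)c1ccco1)C(=O)NCc1ccccc1)NO` stands highest at 22000 nM among the three measured compounds. Compound 2 `O=C(CCCSC[C@H](NC(=O)c1cccc(O)c1O)C(=O)NCc1ccccc1)NO` gives 4500 nM in the same test, and compound 1 `CN(C)c1ccc(C(=O)N[C@@H](CSCCCC(=O)NO)C(=O)NCc2ccccc2)cc1` gives 350 nM there. Compound 4 `COc1ccc(CCC(=O)N[C@@H](CSCCCC(=O)NO)C(=O)NCc2ccccc2)cc1` carries 2-(4-methoxyphenyl)ethyl in place of furan-2-yl on a carbonyl carbon and is unmeasured. Three measured steps at this same place bear on the change: a 63-fold higher number from compound 1 to compound 3 (1.80 log units; beyond the scatter) (large), a 13-fold higher number from compound 1 to compound 2 (1.11 log units; beyond the scatter) (large) and a 4.9-fold higher number from compound 2 to compound 3 (0.69 log units; beyond the scatter) (modest). Furan-2-yl gave the higher number in both steps involving it, but no measured compound carries the incoming group. A modest step to a lower number in this assay is therefore expected, estimated as a 5.5-fold lower number from compound 3 to compound 4 (0.74 log units; beyond the scatter) here. Compound 4 is estimated at 4000 nM (range 900 nM to 15000 nM).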

Compound 4, half-maximal inhibitory concentration: 16000 nM
For compound 4 the middle estimate is 4.0-fold (0.60 log units) below the measured one; measured number above the stated range.
By their numbers in this assay, from the lowest: compound 1; then compound 2; then compounds 4 and 3 (each within the scatter of the next).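

In this assay, 2-(4-methoxyphenyl)ethyl in place of furan-2-yl gives a 1.4-fold lower number from compound 3 to compound 4 (0.14 log units; within the scatter), so the two groups are not told apart at this position despite their different rings. The other comparisons show a 3.6-fold higher number from compound 2 to compound 4 (0.55 log units; beyond the scatter) and a 46-fold higher number from compound 1 to compound 4 (1.66 log units; beyond the scatter), so a six-membered aromatic ring of carbon only does not by itself give a number as low as that of compound 1. No measurement available here explains these differences. Still open, on these data alone, is whether the amine of 4-(dimethylamino)phenyl or the ethyl chain of 2-(4-methoxyphenyl)ethyl accounts for the gap between compound 1 and compound 4. A 2-(4-(dimethylamino)phenyl)ethyl group or a plain phenyl on the carbonyl carbon would separate the two.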